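Cyclohexyl in place of acetamidomethyl on a carbonyl carbon

This account rests on a few compounds, and the source may have more. Where it says the series, first, only, none or still open, it means among the compounds named here.

In an ADME assay on HepG2 2.2.15 cells (Homo sapiens) for cytotoxicity (on this read-out higher numbers stand for lower toxicity in this test and lower numbers for higher toxicity in this test), compound 1 `CCCC(=O)OCCc1c(-c2ccccc2Cl)c2cc(Cl)ccc2[nH]c1=O` gives 52000 nM, compound 2 `CCCCCCCC(=O)OCCc1c(-c2ccccc2Cl)c2cc(Cl)ccc2[nH]c1=O` gives 78000 nM and compound 3 `CC(=O)NCC(=O)OCCc1c(-c2ccccc2Cl)c2cc(Cl)ccc2[nH]c1=O` gives 110000 nM. Two measured steps show where compound 3 stands: a 1.4-fold higher number from compound 2 to compound 3 (0.15 log units; within the scatter), and a 2.1-fold higher number from compound 1 to compound 3 (0.33 log units; beyond the scatter).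

Compound 4 `O=C(OCCc1c(-c2ccccc2Cl)c2cc(Cl)ccc2[nH]c1=O)C1CCCCC1` has cyclohexyl in place of acetamidomethyl on a carbonyl carbon. Like compound 4, compound 1 and compound 2 have only carbon in the group on that carbonyl carbon, and the step between these two measured compounds is small: a 1.5-fold higher number from compound 1 to compound 2 (0.18 log units; within the scatter). The step that brings in acetamido is modest at most, so a large move is not expected when acetamidomethyl leaves. Within the data shown here, no measured compound carries cyclohexyl at this place, and the expected range stays wide.

The expected change is a 1.7-fold lower number from compound 3 to compound 4 (0.23 log units; within the scatter). The estimated value for compound 4 is 65000 nM, with an expected range from 35000 nM to 120000 nM.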

Compound 4, half-maximal cytotoxic concentration: 38000 nM
Beside the measured number, compound 4's estimate is 1.7-fold (0.23 log units) above it; the range from low to high includes it.
By their numbers in this assay, from the lowest: compounds 4, 1, 2 and 3 (each within the scatter of the next, the first and the last beyond it).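

Cyclohexyl in place of acetamidomethyl on a carbonyl carbon gives a 2.9-fold lower number from compound 3 to compound 4 (0.46 log units; beyond the scatter) in this assay and so marks a modest move toward higher toxicity in this test. The groups made only of carbon do not read as one level: cyclohexyl in place of heptyl gives a 2.1-fold lower number from compound 2 to compound 4 (0.31 log units; beyond the scatter) while cyclohexyl in place of propyl gives a 1.4-fold lower number from compound 1 to compound 4 (0.14 log units; within the scatter) and leaves those two compounds inseparable. A ring at this place, like the chains and the acetamidomethyl group, therefore shifts the number modestly at most.

Going by these compounds, a carboxylic acid, an amine or a smaller ring such as cyclopropyl on this carbonyl carbon remains an open case, so how far the number can move here is unknown. Nothing shown explains why these numbers differ.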